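The compounds below may be only part of what the source reports. "The series", "measured", "known", "first", "only" and "open" are said of these compounds alone.

Of the compounds shown here, three built on a shared core have been measured in an assay on CHO cells for displacement of a labelled ligand from transmembrane domain-containing protein TMIGD3 (Homo sapiens); a higher number here means a weaker inhibitor, a lower number a stronger inhibitor. Compound 1 `CC(=O)Oc1cccc2cc(-c3ccsc3)c(=O)oc12` gives 1820 nM. Compound 2 `CC(=O)Oc1ccc2cc(-c3ccsc3)c(=O)oc2c1OC(C)=O`, which carries an extra acetoxy group on the core, gives 3600 nM. Compound 3 `CC(=O)Oc1cccc2cc(-c3cc(Br)cs3)c(=O)oc12`, in which the thiophene ring is differently substituted, gives 4080 nM. Of these three numbers compound 1 has the lowest, but its distance to compound 2 is within the usual scatter, so those two cannot be told apart; only compound 3 stands clearly apart from it.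

Compound 4 `O=c1oc2c(O)cccc2cc1-c1ccsc1` has not yet been measured. It differs from compound 1 in one place: hydrogen in place of acetyl on an oxygen on an aromatic ring. Neither measured step touches this position. The step of a 2.0-fold higher number from compound 1 to compound 2 (0.30 log units; within the scatter) adds an acetoxy group elsewhere on the core, and the step of a 2.2-fold higher number from compound 1 to compound 3 (0.35 log units; beyond the scatter) alters the thiophene ring. Both are small, and nothing here shows what removing the acetyl from the phenolic oxygen does, so no step beyond the scatter is expected in this assay in either direction.

Compound 4 is therefore expected to give about 1800 nM, with a likely range from 600 nM to 5500 nM, which means an expected step of a 1.0-fold lower number from compound 1 to compound 4 (0.00 log units; within the scatter).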

Compound 4, inhibition constant: 2870 nM
Compound 4: middle estimate off by 1.6-fold (0.20 log units), on the low side; low and high end bracket the measured number.
By their numbers in this assay, from the lowest: compounds 1, 4, 2 and 3 (each within the scatter of the next, the first and the last beyond it).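

In this assay, for the compounds shown here, taking the acetyl off the oxygen on the aromatic ring, so that acetoxy becomes hydroxy, gives a 1.6-fold higher number from compound 1 to compound 4 (0.20 log units; within the scatter), and this is the first step that touches this oxygen. The acetyl can therefore be lost on this shared core without a difference that can be told from the usual scatter, so for this pair the acetyl is not needed to keep the number in this range. The data at hand offer no measurement that would explain this result.

On these data alone, it stays open what a different group on this oxygen would do, such as a methyl ether, a longer acyl chain like butyryl, or a carbamate, and whether an amine in place of the oxygen would read alike. As far as these compounds go, it also stays open whether the same swap from acetoxy to hydroxy would read the same way on the core of compound 3, with its 4-bromothiophen-2-yl group, or on compound 2, which carries a second acetoxy group.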